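The compounds below may be only part of what the source reports. "The series", "measured", "known", "first", "only" and "open" are said of these compounds alone.

Compound 1 `COc1ccc(-c2cnc(NC(=O)c3ccc(F)cc3)n2-c2ccccc2)cc1`: 8800 nM
Compound 2 `Cn1c(-c2ccccc2)cnc1NC(=O)c1ccccc1`: > 100000 nM
Compound 3 `Cn1c(-c2cccc(Br)c2)cnc1NC(=O)c1ccc(F)cc1`: > 50000 nM

Among the compounds with values here, in a toxicity assay on THP-1 cells (Homo sapiens) for inhibition (a higher number here means that more compound is tolerated, a lower number that less compound is tolerated), compound 1 gives 8800 nM, the only true number in this small set. Compound 2 reads > 100000 nM, which is a limit of the assay and not a number. Compound 3 reads > 50000 nM, which is also a limit. So compound 1 is the one compound here with a measured half-maximal cytotoxic concentration.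

The next compound, compound 4 `COc1ccc(-c2cnc(NC(=O)c3ccc(F)cc3)n2C(C)C)cc1`, keeps the core of compound 1 but carries isopropyl in place of phenyl on an aromatic nitrogen. Within the data shown here, no two measured compounds differ in one place only, so the size of this change has not been seen directly, and any forecast is loose.

Compounds 2 and 3 both carry a methyl on that nitrogen, though they differ from compound 1 elsewhere too, and neither reached a measurable value in this assay. That points, weakly, towards more compound being tolerated once the phenyl has gone. The expected change is a moderate rise beyond the usual scatter, a 3.0-fold higher number from compound 1 to compound 4 (0.47 log units; beyond the scatter), and this step is only an estimate. For compound 4 the estimated value is 26000 nM, with an expected range from 10000 nM to 90000 nM.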

Compound 4, half-maximal cytotoxic concentration: > 50000 nM
Compound 4 gave a limit, no number; the forecaster's own chance of this, stated with the estimate: 35%; at least 1.9-fold (0.28 log units) between middle value and limit.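

In this assay compound 4 reads > 50000 nM, which is a limit of the assay and not a number. Even so, this is the first pair here that differs in one place only, and it shows that the group on the aromatic nitrogen matters: isopropyl in place of phenyl gives an at least 5.6-fold higher number from compound 1 to compound 4 (0.75 log units; beyond the scatter) and so this single swap is enough to carry the core of compound 1 up to a limit. As far as these compounds go, the true size of the step stays unknown, since only its lower edge can be read: the limit of > 50000 nM in this assay, at which 2 of the 4 values shown sit.

From the compounds shown here alone, what remains open is whether the aromatic ring of the phenyl is what lowers the tolerated concentration, or simply a group of that size on this nitrogen; a cyclohexyl at the same place, which keeps a six-membered ring of carbon but is not aromatic, would separate the two. Going by these compounds, it is also open whether a phenyl that carries an amine would stay close to compound 1 or move towards compound 4, and compound 2 and compound 3 differ from compound 1 in more than one place, so they cannot settle this.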